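Swapping the Trifluoromethoxyphenyl for a Difluorophenyl

A few compounds are considered here, and "the series" means these few. Any claim that something is new, unique, unknown or untested is made for them only; others in the source may bear on it.

The series shares one core, seen in compound 1 `Cc1cc(=O)n(-c2ccc(F)c(F)c2)nc1C(=O)Nc1ccc(Oc2ncnc3sccc23)cc1`, compound 2 `Cc1cc(=O)n(-c2ccccc2C(F)(F)F)nc1C(=O)Nc1ccc(Oc2ncnc3sccc23)c(F)c1` and compound 3 `Cc1cc(=O)n(-c2ccccc2OC(F)(F)F)nc1C(=O)Nc1ccc(Oc2ncnc3sccc23)c(F)c1`, and varies chiefly in the aryl group carried on the aromatic nitrogen. In a functional assay on A549 cells (Homo sapiens) for cytotoxicity, read by MTT assay, with a stated time of 72 h (a lower number here means a stronger inhibitor, a higher number a weaker inhibitor), compound 1 gives 13500 nM and compound 2 gives 16300 nM. Compound 3 reaches only a limit of the assay in this assay, reported as > 40000 nM. Going by the values given here, the single measured step touching this aryl group, an at least 2.4-fold higher number from compound 2 to compound 3 (0.38 log units; beyond the scatter), carries the number from a value up to that limit (the limit of > 40000 nM in this assay, at which 1 of the 3 values shown sits). Compound 4 `Cc1cc(=O)n(-c2ccc(F)c(F)c2)nc1C(=O)Nc1ccc(Oc2ncnc3sccc23)c(F)c1` takes the next step: 3,4-difluorophenyl in place of 2-(trifluoromethoxy)phenyl on an aromatic nitrogen. Among the compounds with values here, its aryl group is the one already present in compound 1, whose value of 13500 nM lies within the scatter of that of compound 2 at 16300 nM. Compound 3 stands only at a limit, so the step is expected to bring the number back down, by an at least 2.8-fold lower number from compound 3 to compound 4 (0.45 log units; beyond the scatter), into the range shared by the two fully measured compounds. Compound 4 is therefore estimated at 14000 nM, between 6000 nM and 35000 nM.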

Compound 4, half-maximal inhibitory concentration: 15700 nM
Estimate against measurement, compound 4: 1.1-fold (0.05 log units) below; measured number inside the range.
By their numbers in this assay, from the lowest: compounds 1, 4 and 2 (each within the scatter of the next). At a limit, above all of these: compound 3.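

In this assay, the aryl change gives an at least 2.5-fold lower number from compound 3 to compound 4 (0.40 log units; beyond the scatter), but this step starts from a limit of the assay, so its size is only a bound: the limit of > 40000 nM in this assay, at which 1 of the 4 values shown sits. At this position on the aromatic nitrogen, 3,4-difluorophenyl and 2-(trifluoromethyl)phenyl cannot be told apart, with a 1.0-fold lower number from compound 2 to compound 4 (0.02 log units; within the scatter), so among the aryl groups shown only 2-(trifluoromethoxy)phenyl stands apart. Going by these compounds alone, the added fluoro, for which the earlier compounds offered no single-place comparison, stays within the scatter, with a 1.2-fold higher number from compound 1 to compound 4 (0.07 log units; within the scatter).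

The 2-(trifluoromethoxy)phenyl and 3,4-difluorophenyl groups differ in more than one feature, so the compounds shown do not say which feature underlies the step. Also open, on these data alone, is how an aryl group carrying an amine, a carboxylic acid or a longer chain would read against compound 1, compound 2 and compound 4.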